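Chain extension on the anilino side: butyl to heptyl

The source may hold more compounds than are shown below. What is called first, only, known or untested is meant among the compounds shown, and "the series" means these compounds.

Among the compounds with values here, compound 1 `CCCCNc1cncc(C(=O)NCc2ccccc2)n1` is the only member of the series with a number in hand. In an ADME assay on Vero cells (Chlorocebus sabaeus) for cytotoxicity, read by microscopy, with a stated time of 6 days (a lower number here means that less compound is tolerated, a higher number that more compound is tolerated), compound 1 gives 100000 nM, so it stands as the sole reference point for tolerated concentration in this set. Within the data shown here, compound 2 `O=C(NCc1ccccc1)c1cnc(Cl)cn1` shares the amide side of the core but carries a chloro in place of the butylamino group; in this assay compound 2 gives "not determined" (no result reported), so it contributes no number and no step can be drawn from it.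

Compound 3 `CCCCCCCNc1cncc(C(=O)NCc2ccccc2)n1` differs from compound 1 in one place: propyl in place of hydrogen on a saturated chain carbon, four bonds along the chain from a nitrogen on an aromatic ring. Among the measured compounds shown here, no step between measured compounds is available to calibrate this change, so the expectation rests on compound 1 alone and on the nature of the change, a longer saturated chain on the same core.

The expected step of a 2.0-fold lower number from compound 1 to compound 3 (0.30 log units; within the scatter) is downward, of modest size, and not clearly beyond the scatter. Compound 3 is therefore expected to give 50000 nM, with a range from 20000 nM to 100000 nM.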

Compound 3, minimum cytotoxic concentration: > 100000 nM
Compound 3 gave a limit, no number (the forecaster's own chance of this, stated with the estimate: 20%); at least 2.0-fold (0.30 log units) between middle value and limit.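

In this assay, propyl in place of hydrogen on a saturated chain carbon, four bonds along the chain from a nitrogen on an aromatic ring, gives a number no lower from compound 1 to compound 3 (the limit leaves the size open). Compound 3 gives > 100000 nM, which is a limit of the assay and not a number. This is the first sign that lengthening butyl to heptyl on the shared core brings no drop in tolerated concentration that this read-out can show, though the size of the step cannot be read, for this reason: the limit of > 100000 nM in this assay, at which 1 of the 3 values shown sits.

On these data alone, whether a decyl chain in place of heptyl would bring the minimum cytotoxic concentration in this assay down to a readable number stays open. Within the data shown here, also open is how a chain carrying an amine or a carboxylic acid would compare with compound 3 in this assay, and a readable number for such a compound would give the series a first measured step of known size.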